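Following the step from compound 3 to compound 4

A few compounds are considered here, and "the series" means these few. Any claim that something is new, unique, unknown or untested is made for them only; others in the source may bear on it.

Measured in a functional assay on DU-145 cells (Homo sapiens) for inhibition, read by trypan blue exclusion, with a stated time of 96 h; a lower number here means a stronger inhibitor of growth, a higher number a weaker inhibitor of growth:
- compound 1 `Cc1ccc(S/C(=C/c2ccc(Br)cc2)C(=O)c2ccc(Cl)cc2)cc1`: 25000 nM
- compound 2 `Cc1ccc(S/C(=C/c2ccc(N(C)C)cc2)C(=O)c2ccc(Cl)cc2)cc1`: > 100000 nM (a limit)
- compound 3 `Cc1ccc(S/C(=C/c2c(O)cc(O)cc2O)C(=O)c2ccc(Cl)cc2)cc1`: > 100000 nM (a limit)

Compound 3 has no number of its own and sits at the limit of > 100000 nM in this assay, at which 2 of the 3 values shown sit.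

Compound 4 `COc1ccc(/C=C(/Sc2ccc(C)cc2)C(=O)c2ccc(Cl)cc2)cc1O` differs from it as follows: 3-hydroxy-4-methoxyphenyl in place of 2,4,6-trihydroxyphenyl on a double-bonded chain carbon bound to a double-bonded chain carbon.

The measured steps that bear on this change are an at least 4.0-fold higher number from compound 1 to compound 3 (0.60 log units; beyond the scatter) and an at least 4.0-fold higher number from compound 1 to compound 2 (0.60 log units; beyond the scatter). From the compounds shown here alone, both replace the group at this place or on its ring, and both stop at a limit, so their true sizes are unknown. The third is a step that the two limits leave unreadable from compound 2 to compound 3.

The only readable anchor in this assay is compound 1 at 25000 nM, so a value of that order is expected for compound 4.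

A further limit is still possible for compound 4.

The estimated step, towards a lower number, is an at least 5.0-fold lower number from compound 3 to compound 4 (0.69 log units; beyond the scatter).

The estimate for compound 4 is 20000 nM, with an expected range of 4000 nM to 100000 nM.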

Compound 4, concentration for 50% growth inhibition: 1000 nM
Estimate against measurement, compound 4: 20-fold (1.30 log units) above; the measured number lies below the stated range.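

In this assay, the earlier changes at this place on the double-bonded chain carbon showed only moves to a higher number, whereas 3-hydroxy-4-methoxyphenyl in place of 4-bromophenyl gives a 25-fold lower number from compound 1 to compound 4 (1.40 log units; beyond the scatter). A hydroxy group on this ring does not settle the outcome on its own: 2,4,6-trihydroxyphenyl and 3-hydroxy-4-methoxyphenyl both carry one, yet the change between them gives an at least 100-fold lower number from compound 3 to compound 4 (2.00 log units; beyond the scatter), and replacing 4-(dimethylamino)phenyl gives an at least 100-fold lower number from compound 2 to compound 4 (2.00 log units; beyond the scatter). Both of these steps start from a limit, so their true sizes remain unknown: the limit of > 100000 nM in this assay, at which 2 of the 4 values shown sit.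

The change alters the hydroxy groups and brings in a methoxy group together, so the compounds shown do not separate the two. From the compounds shown here alone, it also remains open whether an amine or a carboxylic acid in place of the hydroxy group of compound 4 would keep the growth inhibition.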